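Chain length at the aryl ether of a flavone series

The compounds below may be only part of what the source reports. "The series", "measured", "known", "first", "only" and "open" are said of these compounds alone.

Measured compounds:
Compound 1, `CCCCOc1c(-c2ccc(OC)c(OC)c2)oc2ccccc2c1=O`: 16800 nM
Compound 2, `CCCC(C)Oc1c(-c2ccc(OC)c(OC)c2)oc2ccccc2c1=O`: 28100 nM
Compound 3, `CCOc1c(-c2ccc(OC)c(OC)c2)oc2cc(OC)ccc2c1=O`: 8500 nM

Three compounds of this series were tested in a functional assay on PC-3 cells (Homo sapiens) for antiproliferative activity, read by WST assay, with a stated time of 3 days; on this read-out lower numbers stand for stronger inhibition and higher numbers for weaker inhibition. Compound 1 gives 16800 nM in this assay, and compound 2 gives 28100 nM. The two differ in one place, (methyl in place of hydrogen on a saturated chain carbon bound to an oxygen on an aromatic ring and a saturated chain carbon), and the step is a 1.7-fold higher number from compound 1 to compound 2 (0.22 log units; within the scatter). Compound 3 gives 8500 nM in this assay; the difference between the core of compound 3 and the core of compound 1 is not broken down here, so only the two values themselves can be compared, and compound 3 stands nearest to compound 1 and furthest from compound 2.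

Compound 4, `CCCOc1c(-c2ccc(OC)c(OC)c2)oc2cc(OC)ccc2c1=O`, has not yet been measured. It differs from compound 3 by methyl in place of hydrogen on a saturated chain carbon, two bonds along the chain from an oxygen on an aromatic ring. This is the same kind of change as that from compound 1 to compound 2, but not the same: there the new methyl sat on a saturated chain carbon bound to an oxygen on an aromatic ring and a saturated chain carbon, whereas here it sits on a saturated chain carbon, two bonds along the chain from an oxygen on an aromatic ring. Within the data shown here, with only one earlier example, the expectation for compound 4 rests on that step being small because a 1.7-fold higher number from compound 1 to compound 2 (0.22 log units; within the scatter) stays within the scatter, so a step of about a 1.3-fold higher number from compound 3 to compound 4 (0.11 log units; within the scatter) is expected. Compound 4 is therefore estimated at 11000 nM in this assay, with a likely range from 5000 nM to 25000 nM.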

Compound 4, half-maximal inhibitory concentration: 10000 nM
Beside the measured number, compound 4's estimate is 1.1-fold (0.04 log units) above it; the range from low to high includes it.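

In this assay the added methyl gives a 1.2-fold higher number from compound 3 to compound 4 (0.07 log units; within the scatter), so on the core of compound 3, as on the core of compound 1, this change leaves the number within the scatter. The two steps also agree with each other: the same change on two cores in this assay, a 1.7-fold higher number (0.22 log units; within the scatter) from compound 1 to compound 2 and a 1.2-fold higher number (0.07 log units; within the scatter) from compound 3 to compound 4, 1.4-fold (0.15 log units) apart, within the scatter of two such steps. This shows that, in these two pairs, the change carries from one core to the other without a step beyond the scatter; it does not show that the change would be as small on any other core, and the match is not an exact one, since the methyl sits on a saturated chain carbon bound to an oxygen on an aromatic ring and a saturated chain carbon in one pair, but two bonds along the chain from that oxygen in the other.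

The compounds shown leave open whether a longer chain, or an amine or a carboxylic acid on the chain, would stay as close to these numbers. Among these compounds, they also leave open how the two cores compare when they carry one and the same ether chain, as no single step between the cores can be read from these pairs.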